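The source may report more compounds than this note shows. Statements on the series, on what has been measured and on what is new or still open speak of the compounds shown alone.

Values in a functional assay on A-375 cells (Homo sapiens) for antiproliferative activity, read by MTT assay, with a stated time of 72 h; on this read-out higher numbers stand for weaker inhibition and lower numbers for stronger inhibition:
- compound 1 `O=C1COc2ccc(-c3cnc(Cl)c(NS(=O)(=O)c4ccc(F)cc4)c3)cc2N1C1CCCCC1`: > 40000 nM (a limit of the assay)
- compound 2 `Cc1ccc(N2C(=O)COc3ccc(-c4cnc(Cl)c(NS(=O)(=O)c5ccc(F)cc5)c4)cc32)cc1`: 38900 nM

Among the compounds with values here, compound 2 gives 38900 nM, the only actual number so far, while the other result sits at the limit of > 40000 nM in this assay, at which 1 of the 2 values shown sits. Compound 3 `O=C1COc2ccc(-c3cnc(Cl)c(NS(=O)(=O)c4ccc(F)cc4)c3)cc2N1C1CC1` carries cyclopropyl in place of 4-methylphenyl on an amide-type nitrogen in a ring. Within the data shown here, one measured step bears on this place: an at least 1.0-fold lower number from compound 1 to compound 2 (0.01 log units; that floor lies within the scatter), with cyclohexyl leaving and 4-methylphenyl entering. On that basis, no step beyond the scatter is expected in this assay. The expected result is a 1.0-fold higher number from compound 2 to compound 3 (0.01 log units; within the scatter). For compound 3 the estimate is 40000 nM, with an expected range from 18000 nM to 80000 nM.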

Compound 3, half-maximal inhibitory concentration: 21800 nM
Estimate against measurement, compound 3: 1.8-fold (0.26 log units) above, within the range that was stated.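

In this assay, cyclopropyl in place of 4-methylphenyl on the amide-type nitrogen gives a 1.8-fold lower number from compound 2 to compound 3 (0.25 log units; within the scatter). Compound 1 is held at a limit, so cyclopropyl in place of cyclohexyl yields only a floor, an at least 1.8-fold lower number from compound 1 to compound 3 (0.26 log units; that floor lies within the scatter), and no exact size: the limit of > 40000 nM in this assay, at which 1 of the 3 values shown sits. Compound 3 thus shows that a three-membered non-aromatic ring at this place gives a measurable number, with no step beyond the scatter among the compounds shown.

Open, going by these compounds, is whether the amide hydrogen, or a longer chain ending in an amine or a carboxylic acid, would move the number at this nitrogen beyond the scatter. The compounds shown also leave open how changes elsewhere on the shared core would read.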